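The source may report more compounds than this note shows. Statements on the series, on what has been measured and on what is new or still open speak of the compounds shown alone.

Compound 1, `N#Cc1c(-c2c[nH]c3ccccc23)cc(-c2ccc3c(c2)CCCC3)[nH]c1=S`, in an ADME assay on RAW264.7 cells (Mus musculus) for cytotoxicity, with a stated time of 24 h (on this read-out lower numbers stand for stronger inhibition and higher numbers for weaker inhibition), gives > 100000 nM, which is a limit of the assay and not a number.
Compound 2, `COc1ccc(-c2cc(-c3ccc4c(c3)CCCC4)nc(NCc3ccccc3)c2C#N)cc1OC`, in this assay gives 4900 nM.
Compound 3, `CC(C)c1ccc(-c2cc(-c3ccc4c(c3)CCCC4)nc(NCc3ccccc3)c2C#N)cc1`, in this assay gives > 50000 nM, again a limit of the assay.

Compound 2 is therefore the only one of the three with an actual number in this assay; the other two sit at limits, as the limit of > 100000 nM in this assay, at which 1 of the 3 values shown sits, and the limit of > 50000 nM in this assay, at which 1 of the 3 values shown sits, show. For the measured compounds named here, the one measured step with a single change is an at least 10-fold higher number from compound 2 to compound 3 (1.00 log units; beyond the scatter), so swapping one aryl group for another moved the read-out from a number to a limit.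

Compound 4, `COc1ccc(-c2cc(-c3ccc4c(c3)CCCC4)nc(OCC(=O)NN)c2C#N)cc1OC`, has not yet been measured. Its change from compound 2 is (aminocarbamoyl)methoxy in place of benzylamino on an aromatic carbon. Going by the values given here, no measured step touches this position, so the change at the aryl group is only a loose guide. A step of similar size in the same direction, toward weaker inhibition, is expected, a 4.1-fold higher number from compound 2 to compound 4 (0.61 log units; beyond the scatter). For compound 4 in this assay the estimate is 20000 nM, with a range from 4000 nM to 100000 nM, and a fair chance that only a limit is reported.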

Compound 4, half-maximal inhibitory concentration: 3100 nM
The estimate for compound 4 lay 6.5-fold (0.81 log units) above the measured number; measured number below the stated range.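

Placing (aminocarbamoyl)methoxy in place of benzylamino, on the aromatic carbon next to the ring nitrogen, gives a 1.6-fold lower number from compound 2 to compound 4 (0.20 log units; within the scatter) in this assay. The two groups differ a good deal: the one that leaves carries a six-membered aromatic ring of carbon only, the one that enters has no ring and contains oxygen, yet in this single pair the read-out does not separate them. For the compounds shown here, this is the first view of this position, since the earlier step, an at least 10-fold higher number from compound 2 to compound 3 (1.00 log units; beyond the scatter), concerned the aryl group at another place, and nothing measured here explains why the new change leaves the number in place.

The compounds shown leave open whether a plain amine, a carboxylic acid or a longer chain on this carbon would give a similar number. Also open, going by these compounds, is how (aminocarbamoyl)methoxy behaves when 4-isopropylphenyl stands in place of 3,4-dimethoxyphenyl.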